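Adding a hydroxypropyl arm to compound 1

The source may report more compounds than this note shows. Statements on the series, on what has been measured and on what is new or still open speak of the compounds shown alone.

compound 1 : `CCCCCCCCc1ccc(CCC(N)CO)cc1` — > 10 mg/kg
compound 2 : `CCCCCCCOc1ccc(CC[C@@](N)(CO)CCC)cc1` — 0.63 mg/kg

The study concerns a functional assay on the whole organism (spleen, spleen) with Rattus norvegicus as the target; a lower number here means that less compound is needed, a higher number that more compound is needed for the effect. In this assay compound 1 gives > 10 mg/kg, a limit of the assay rather than a number, so compound 1 stands at the limit of > 10 mg/kg in this assay, at which 1 of the 2 values shown sits. Compound 2 gives 0.63 mg/kg in this assay, a measured value well inside the range of the method.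

Compound 3, `CCCCCCCCc1ccc(CCC(N)(CO)CCCO)cc1`, has not yet been tested. It differs from compound 1 in one place: 3-hydroxypropyl in place of hydrogen on a saturated chain carbon bound to an amine nitrogen and two saturated chain carbons. Among the compounds with values here, since compound 1 is known only as a limit, no measured step within this pair shows how this assay answers such a change, and the two measured values show only that compound 2 needs far less compound than the limit reached by compound 1.

The step from compound 1 to compound 3 is expected to bring a modest gain, an at least 3.3-fold lower number from compound 1 to compound 3 (0.52 log units; beyond the scatter). Compound 3 is therefore estimated at 3 mg/kg, within 0.6 mg/kg to 10 mg/kg.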

Compound 3, dose for 50% inhibition: 0.085 mg/kg
Beside the measured number, compound 3's estimate is 35-fold (1.55 log units) above it; the measured number lies below the stated range.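

In this assay, placing a 3-hydroxypropyl group on the saturated chain carbon bound to an amine nitrogen and two saturated chain carbons brings an at least 110-fold lower number from compound 1 to compound 3 (2.07 log units; beyond the scatter). Within the data shown here, this is the first measured step at this position, and it shows that the position accepts the added arm and that the read-out responds strongly to this change. The printed size is only a bound, not an exact measure, because compound 1 is known only as a limit: the limit of > 10 mg/kg in this assay, at which 1 of the 3 values shown sits.

The compounds shown leave open whether the terminal hydroxyl of the arm matters, or whether a plain propyl group, a shorter hydroxyethyl chain, or a terminal amine or carboxylic acid would serve equally at this carbon. They also leave open which of the two mirror-image forms at this carbon accounts for the effect of compound 3.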